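Trading a Carboxy Group for a Carbamoylcyclopropyl

The source may hold more compounds than are shown below. What is called first, only, known or untested is meant among the compounds shown, and "the series" means these compounds.

Compound 1 `Cc1nc(-c2ccc(C(F)(F)F)cc2)sc1CNc1ccc(C(=O)O)cc1` is the weakest of the three measured compounds in a functional assay on CHO cells for agonist activity at Free fatty acid receptor 1 (Homo sapiens), read by a luciferase reporter (a higher number here means a larger maximal response, a lower number a smaller maximal response), where compound 1 reaches 10%. Compound 2 `O=C(O)[C@@H]1C[C@H]1c1ccc(NCc2cccc(Oc3ccccc3)c2)cc1` gives 64% and compound 3 `O=C(CCc1ccc(NCc2cccc(Oc3ccccc3)c2)cc1)N1CCCC1` gives 46%, so compound 1 lies well below both, beyond the scatter in each case.

The unmeasured compound 4 `Cc1nc(-c2ccc(C(F)(F)F)cc2)sc1CNc1ccc([C@H]2C[C@@H]2C(N)=O)cc1` keeps the core of compound 1 and differs from it in one place: 2-carbamoylcyclopropyl in place of carboxy on an aromatic carbon. Among the measured compounds shown here, no measured pair shows this exact change. The closest guide is the step of a number 18 percentage points lower from compound 2 to compound 3 (beyond the scatter), in which 2-((pyrrolidin-1-yl)carbonyl)ethyl replaces 2-carboxycyclopropyl and the maximal response falls modestly. That step, however, starts from a much higher value than compound 1, and compound 4 also gains a three-membered non-aromatic ring of carbon only, which compound 2 carries and compound 1 does not. Taken together, a small shift in either direction, possibly within the scatter, seems the most reasonable expectation in this assay. For compound 4 the maximal response in this assay is estimated at 20%, within a range from 5% to 45%. This corresponds to an expected step of a number 10 percentage points higher from compound 1 to compound 4 (within the scatter).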

Compound 4, largest response reached (reported as percent of maximum), in percent of the reference or control that the assay uses: 80%
The estimate for compound 4 lay 60 percentage points below the measured number; the whole stated range lies below it.
By their numbers in this assay, from the lowest: compound 1; then compound 3; then compound 2; then compound 4.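

In this assay the aromatic carbon para to a large group accepts much more than a carboxy group on this core: with 2-carbamoylcyclopropyl in its place, the result is a number 70 percentage points higher from compound 1 to compound 4 (beyond the scatter), so a carboxy group at this position is not required for a large maximal response on the core of compound 1. Among the compounds shown here, the only earlier step, a number 18 percentage points lower from compound 2 to compound 3 (beyond the scatter), also removed a carboxy-bearing group in favour of an amide-bearing one, but it went the opposite way on a different core and with a different amide chain, so the direction of such a change does not carry over between the two series. Nothing measured here explains the size of the new step.

On these data alone, the new step changes the three-membered ring and the carbamoyl group together, so the contribution of each stays open; a 2-carboxycyclopropyl group on this core, a carbamoyl group placed directly on the aromatic carbon, or an open 2-carbamoylethyl chain would separate them. The compounds shown also leave open how the mirror-image form of the 2-carbamoylcyclopropyl group, with both stereocentres inverted, would behave.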